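A few compounds are considered here, and "the series" means these few. Any claim that something is new, unique, unknown or untested is made for them only; others in the source may bear on it.

Of the compounds shown here, three have so far been measured in a functional assay on NCI-H292 cells (Homo sapiens) for cytotoxicity, read by MTT assay, with a stated time of 72 h, tested at 2.5 ug/mL; on this read-out lower numbers stand for less inhibition of growth and higher numbers for more inhibition of growth at the one concentration tested. Compound 1 `O=C1NC(=S)/C(=C/c2ccc(Br)cc2)S1` gives 1.19%. Compound 3 `O=C1NC(=S)/C(=C/c2ccc(F)cc2)S1` gives 17.5%, and it is turned into compound 1 by a single change, (bromo in place of fluoro on an aromatic carbon), for which the measured step is a number 16.3 percentage points lower from compound 3 to compound 1 (beyond the scatter). Compound 2 `O=C1NC(=S)/C(=C/c2cccc(F)c2)S1` gives 3.43% in this assay; this value sits close to that of compound 1, within the scatter, and is a lower number than that of compound 3, beyond the scatter. Compound 2 and compound 3 are built from the same atoms joined differently, and the difference between the two cores is not broken down here.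

Compound 4 `O=C1NC(=S)/C(=C/c2cccc(Br)c2)S1` has not yet been measured in this assay. It arises from compound 2 by bromo in place of fluoro on an aromatic carbon. Among the measured compounds shown here, this is the same kind of change as the one leading from compound 3 to compound 1, but the place is not identical: in the earlier pair the exchanged group sits para to a group of 8 heavy atoms, whereas in compound 4 it sits meta to a group of 8 heavy atoms. Because the earlier step was a number 16.3 percentage points lower from compound 3 to compound 1 (beyond the scatter), a lowering might be looked for here too, yet compound 2 already gives 3.43%, so there is little room left to fall. For compound 4 the expected step is therefore small, a number 1.9 percentage points lower from compound 2 to compound 4 (within the scatter), and would lie within the scatter. Compound 4 is expected to give roughly 1.5% in this assay, with a likely range from 0% to 10%.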

Compound 4, percent growth inhibition at one concentration: 11.1%
Compound 4: middle estimate off by 9.6 percentage points, on the low side, outside the stated range (above it).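

In this assay, bromo in place of fluoro on an aromatic carbon, meta to a group of 8 heavy atoms, gives a number 7.7 percentage points higher from compound 2 to compound 4 (within the scatter), so the clear lowering seen in the earlier pair does not carry over to this core, and the two steps differ: the same change on two cores in this assay, a number 16.3 percentage points lower (beyond the scatter) from compound 3 to compound 1 and a number 7.7 percentage points higher (within the scatter) from compound 2 to compound 4, 24 percentage points apart, beyond the scatter of two such steps The change therefore cannot be moved from one core to the other in this series as a fixed step, and its size on the core of compound 3 says little about its size on the core of compound 2. This does not show that bromo raises the read-out on the core of compound 2, since that step stands within the scatter, nor does it show why the two steps differ, as each core supplies a single pair and nothing here separates the place of the exchange from any other difference between the cores.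

The compounds shown carry only fluoro or bromo on the aromatic ring, so it stays open how chloro, methoxy, an amine or a carboxylic acid would behave there on either core. Among the compounds shown here, with only two pairs at one concentration, it also stays open whether the difference between the steps would hold at other concentrations.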